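Cytotoxicity of Two Diaryl Ethers and a Piperazine Analogue

The source may hold more compounds than are shown below. What is called first, only, known or untested is meant among the compounds shown, and "the series" means these compounds.

Compound 1 `COCCNC(=O)/C=C/c1cnc(Nc2ccc(C#N)cc2)nc1Oc1c(C)cc(C#N)cc1C` was tested in an ADME assay on TZM cells (Homo sapiens) for cytotoxicity, with a stated time of 1 days; a lower number here means that less compound is tolerated, a higher number that more compound is tolerated. In this assay compound 1 gives only a limit, > 213 nM. Compound 2 `Cc1cc(C#N)cc(C)c1Oc1nc(Nc2ccc(C#N)cc2)ncc1/C=C/C(=O)NCC1CCN(S(C)(=O)=O)C1` differs from it in one place. In this assay compound 2 likewise gives only a limit, > 175 nM. The step that the two limits leave unreadable from compound 1 to compound 2 therefore cannot be read, since both values sit at limits (the limit of > 175 nM in this assay, at which 1 of the 2 values shown sits, and (the limit of > 213 nM in this assay, at which 1 of the 2 values shown sits)). Compound 2 thus stands at a limit with no number of its own.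

Compound 3 `Cc1cc(C#N)cc(C)c1Oc1nc(Nc2ccc(C#N)cc2)ncc1/C=C/C(=O)N1CCN(C=O)CC1` carries the change (4-formylpiperazin-1-yl in place of ((1-(methylsulfonyl)pyrrolidin-3-yl)methyl)amino on a carbonyl carbon). Going by the values given here, the only measured step bears on a different part of the molecule and is itself unreadable, so no size or direction can be drawn from it. Compound 3 is therefore expected to behave like its neighbours and is estimated at 200 nM in this assay, with a range from 100 nM to 2000 nM. The step that the limit leaves unreadable from compound 2 to compound 3 is accordingly expected to be none beyond the scatter, and a limit rather than a number is the likely outcome.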

Compound 3, half-maximal cytotoxic concentration: > 197 nM
Compound 3 gave a limit, no number (the forecaster's own chance of this, stated with the estimate: 80%); the middle value does not contradict the limit.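

In this assay compound 3 gives only a limit, > 197 nM. Going by these compounds alone, with compound 1 and compound 2 also at limits, no step among the three can be read. The compounds shown leave open where the half-maximal cytotoxic concentration of each actually lies, and whether these changes shift it at all.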